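This account rests on a few compounds, and the source may have more. Where it says the series, first, only, none or still open, it means among the compounds named here.

Compound 1 `O=c1cc(CC(O)(COCc2ccccc2)COCc2ccccc2)[nH]c(=O)[nH]1` is the parent of the set. In a functional assay on SW-620 cells (Homo sapiens) for antiproliferative activity, read by MTT assay, with a stated time of 72 h (on this read-out lower numbers stand for stronger inhibition and higher numbers for weaker inhibition), compound 1 gives only a limit, > 100000 nM. Compound 2 `COCn1c(CC(O)(COCc2ccccc2)COCc2ccccc2)cc(=O)[nH]c1=O` carries a methoxymethyl in place of hydrogen on an aromatic nitrogen. In this assay compound 2 likewise returns only a limit, > 100000 nM. The step between them, a step that the two limits leave unreadable from compound 1 to compound 2, therefore has no readable size. Compound 3 `O=c1cc(CC(COCc2ccccc2)COCc2ccccc2)[nH]c(=O)[nH]1` has hydrogen in place of hydroxy on a saturated chain carbon bound to three saturated chain carbons. In this assay compound 3 also reaches only a limit, > 100000 nM. The step that the two limits leave unreadable from compound 1 to compound 3 is equally unreadable. On the numbers shown, compound 3 stands at the limit where every value of the set sits, (the limit of > 100000 nM in this assay, at which 3 of the 3 values shown sit).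

Compound 4 `COCn1c(CC(COCc2ccccc2)COCc2ccccc2)cc(=O)[nH]c1=O` has not yet been tested in this assay. It differs from compound 3 by methoxymethyl in place of hydrogen on an aromatic nitrogen. The same change was made once before, as the step that the two limits leave unreadable from compound 1 to compound 2, and its size could not be read. Among the measured compounds shown here, no measured step thus shows a direction for the change. The expected step is a number no higher from compound 3 to compound 4 (the limit leaves the size open), that is, none beyond the scatter. Compound 4 is accordingly estimated at 100000 nM in this assay, between 20000 nM and 500000 nM, with a limit rather than a number the most probable report.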

Compound 4, half-maximal inhibitory concentration: > 100000 nM
Compound 4: a limit, no number; the forecaster's own chance of this, stated with the estimate: 85%; the middle value sits exactly at the limit.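

In this assay, compound 4 gives only a limit, so its steps from compound 3 and from compound 2 cannot be read, and no new step size emerges: the limit of > 100000 nM in this assay, at which 4 of the 4 values shown sit.

The compounds shown leave open whether either change, methoxymethyl in place of hydrogen or hydrogen in place of hydroxy, alters the read-out at all.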